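The compounds below may be only part of what the source reports. "The series", "measured", "known", "first", "only" and "open" are said of these compounds alone.

In a functional assay on KYSE-450 cells (Homo sapiens) for inhibition, read by CCK-8 assay, with a stated time of 48 h (a lower number here means a stronger inhibitor, a higher number a weaker inhibitor), compound 1 `COc1cc(N(Cc2ccc(Br)cc2)C(=O)CSC(=S)N2CCN(C(=O)OC(C)(C)C)CC2)cc(OC)c1OC` gives 10700 nM, while compound 2 `COc1ccc(CN(C(=O)CSC(=S)N2CCN(C(=O)OC(C)(C)C)CC2)c2cc(OC)c(OC)c(OC)c2)cc1F` gives 2410 nM, the lower of the two numbers and so the stronger inhibitor of this pair. Compound 3 `COc1ccc(CN(C(=O)CSC(=S)N2CCN(C(=O)OC(C)(C)C)CC2)c2cc(OC)c(OC)c(OC)c2)cc1N=[N+]=[N-]` departs from compound 2 in a single group: azido in place of fluoro on an aromatic carbon. Going by the values given here, only one measured step bears on this change: a 4.4-fold lower number from compound 1 to compound 2 (0.65 log units; beyond the scatter). It shows that the number can move when this aromatic group is altered, but azido played no part in it. Among the compounds with values here, no measured compound here carries azido, so the data fix no direction. A modest move either way, of about the size of that one step, remains possible, with a slight loss the more cautious guess. The expected value for compound 3 is 3000 nM, estimated to lie between 900 nM and 10000 nM. This estimate amounts to an expected 1.2-fold higher number from compound 2 to compound 3 (0.10 log units; within the scatter).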

Compound 3, half-maximal inhibitory concentration: 840 nM
For compound 3 the middle estimate is 3.6-fold (0.55 log units) above the measured one, and the stated range ends above it.
By their numbers in this assay, from the lowest: compound 3; then compound 2; then compound 1.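

In this assay, azido in place of fluoro on the aromatic carbon ortho to a methoxy group gives a 2.9-fold lower number from compound 2 to compound 3 (0.46 log units; beyond the scatter). This position therefore accepts a group of 3 heavy atoms in place of a single fluorine, and the number still falls, which makes compound 3 the strongest inhibitor of the three. Taken as a whole, 3-azido-4-methoxyphenyl in place of 4-bromophenyl gives a 13-fold lower number from compound 1 to compound 3 (1.11 log units; beyond the scatter), and nothing measured here accounts for this gain.

As far as these compounds go, it remains open whether an amine or a nitrile on this same aromatic carbon would lower the number further or raise it again. From the compounds shown here alone, it is also open whether a hydroxyl in place of the methoxy group would keep the number this low.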